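This account rests on a few compounds, and the source may have more. Where it says the series, first, only, none or still open, it means among the compounds named here.

Measured in a functional assay on the whole organism with Scenedesmus acutus as the target, with a stated time of 20 h; a lower number here means a stronger inhibitor, a higher number a weaker inhibitor:
- Compound 1 `S=c1s/c(=N\c2ccc(Br)cc2)n2n1CCCC2`: 550 nM
- Compound 2 `S=c1s/c(=N\c2ccc(Cl)cc2)n2n1CCCC2`: 550 nM

Among the measured compounds shown here, compound 2, at 550 nM, stands level with the only other measured compound, so neither can be called the better inhibitor. The next structure, compound 3 `S=c1s/c(=N\c2ccccc2)n2n1CCCC2`, has hydrogen in place of chloro on an aromatic carbon, para to a large group: hydrogen in place of chloro on an aromatic carbon.

For the measured compounds named here, only one measured step bears on this change. Going no change at the digits printed from compound 1 to compound 2 (within the scatter), chloro replaced bromo at that same place and the number stayed within the scatter. That step exchanges one halogen for another, so it gives no direct measure of what happens when the halogen is absent altogether. Going by the values given here, no measured compound yet has hydrogen there. A modest move toward weaker inhibition in this assay is therefore expected, though a result within the scatter would be no surprise. The expected size of the step is a 1.5-fold higher number from compound 2 to compound 3 (0.19 log units; within the scatter).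

For compound 3 the estimated value is 850 nM, with an expected range of 300 nM to 2500 nM.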

Compound 3, half-maximal inhibitory concentration: 4370 nM
Beside the measured number, compound 3's estimate is 5.1-fold (0.71 log units) below it; measured number outside the range, above it.
By their numbers in this assay, from the lowest: compounds 1 and 2 (each within the scatter of the next); then compound 3.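

Taking the halogen away altogether matters in this assay: hydrogen in place of chloro gives a 7.9-fold higher number from compound 2 to compound 3 (0.90 log units; beyond the scatter) and hydrogen in place of bromo gives a 7.9-fold higher number from compound 1 to compound 3 (0.90 log units; beyond the scatter), and both steps lie beyond the scatter. The earlier pair showed only that chloro and bromo could not be told apart on this aromatic carbon, para to a large group, and that exchange of one halogen for another could not reveal whether a halogen was needed at all. Among these three compounds, the two that carry a halogen at this position are the stronger inhibitors, while compound 3, with hydrogen there, is the weakest.

The compounds shown leave open whether a halogen as such is what counts, since fluoro, iodo, methyl, methoxy, trifluoromethyl and an amine at this place could each fall near either the halogen pair or compound 3. Why hydrogen gives the higher number also stays open, as nothing available here bears on the reason for this step.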